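The source may report more compounds than this note shows. Statements on the series, on what has been measured and on what is new or still open speak of the compounds shown alone.

Measured compounds in the series:

- compound 1, `Cc1cc(-n2cnc3ccccc32)c(S(C)(=O)=O)cc1C(=O)N=C(N)N`: 100 nM
- compound 2, `Cc1cc(C(F)(F)F)c(S(C)(=O)=O)cc1C(=O)N=C(N)N`: 37 nM
- compound 3, `CS(=O)(=O)c1cc(C(=O)N=C(N)N)ccc1C(F)(F)F`: 140 nM

Among the compounds with values here, in a functional assay for inhibition of sodium/hydrogen exchanger (Oryctolagus cuniculus) (a higher number here means a weaker inhibitor, a lower number a stronger inhibitor), compound 3 gives the highest of the three numbers recorded so far; against compound 1 it sits within the scatter, and only the gap to compound 2 is beyond it, which is the single step between compounds differing in one place: a 3.8-fold higher number from compound 2 to compound 3 (0.58 log units; beyond the scatter).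

The next compound, compound 4, `CS(=O)(=O)c1cc(C(=O)N=C(N)N)ccc1-n1ccc(=O)cc1`, has not been measured. It differs from compound 3 as follows: a group of 7 heavy atoms (5 carbon, 1 nitrogen, 1 oxygen; one six-membered aromatic ring with 1 hetero atom) in place of a group of 4 heavy atoms (1 carbon, 3 fluorine; no ring), on an aromatic carbon.

Within the data shown here, no measured step exchanges the trifluoromethyl for a ring, so the recorded step from compound 2 to compound 3 bears on it only indirectly, as a guide to how much a single change at the core has moved this assay. The nearest comparison is compound 1 against compound 2: compound 1 carries a ring in place of the trifluoromethyl of compound 2, and compound 1 gives 100 nM where compound 2 gives 37 nM, a higher number with the ring. The group entering compound 4 is a different ring, so this is a loose guide. A modest shift toward a higher number is expected, a 1.8-fold higher number from compound 3 to compound 4 (0.25 log units; within the scatter), with wide uncertainty. For compound 4 the estimate is 250 nM, between 80 nM and 800 nM.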

Compound 4, half-maximal inhibitory concentration: 710 nM
Compound 4: the middle estimate sits 2.8-fold (0.45 log units) below what was measured; low and high end bracket the measured number.
By their numbers in this assay, from the lowest: compound 2; then compounds 1 and 3 (each within the scatter of the next); then compound 4.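

In this assay, replacing the trifluoromethyl ortho to a methylsulfonyl group with the ring group of 7 heavy atoms gives a 5.1-fold higher number from compound 3 to compound 4 (0.71 log units; beyond the scatter), which shows that this position responds to the choice of group on a core without the methyl. The ring exchange in the methyl-bearing pair points the same way, with compound 2 at 37 nM and compound 1 at 100 nM, so both ring-for-trifluoromethyl exchanges shown give a higher number, although the two rings and the two cores differ and two pairs make only a narrow pattern. No measurement available here accounts for the shift in compound 4.

As far as these compounds go, it remains open whether the methyl on the aromatic carbon, which separates compound 2 from compound 3, would lower the number if added to compound 4, since that compound has no measured partner carrying it. From the compounds shown here alone, it is also open how non-ring groups at this position, such as an amine, a methoxy group or a chlorine atom, would compare with trifluoromethyl and with the two rings, so the series does not yet separate the effect of having a ring from the effect of that particular ring.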